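The source may report more compounds than this note shows. Statements on the series, on what has been measured and on what is new or still open speak of the compounds shown alone.

Compound 1 `CCN1CCN(c2ccc(S(=O)(=O)Oc3cccc(OC)c3)cc2)C1=O`: 22000 nM
Compound 2 `CCN1CCN(c2ccc(S(=O)(=O)Oc3cccc(F)c3)cc2)C1=O`: > 100000 nM
Compound 3 `CCN1CCN(c2ccc(S(=O)(=O)Oc3ccc(OC)cc3)cc2)C1=O`: 60000 nM

In a functional assay on HT-29 cells (Homo sapiens) for antiproliferative activity, read by sulforhodamine B assay, with a stated time of 48 h (a higher number here means a weaker inhibitor, a lower number a stronger inhibitor), compound 1 gives 22000 nM, the lower of the two actual numbers, which makes it the stronger inhibitor of that pair. The nearest number belongs to compound 3, at 60000 nM. For compound 2 the assay reports only a limit, > 100000 nM.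

Compound 4 `CCCN1CCN(c2ccc(S(=O)(=O)Oc3cccc(OC)c3)cc2)C1=O` keeps the 3-methoxyphenyl group of compound 1 and changes ethyl to propyl: methyl in place of hydrogen on a saturated chain carbon, two bonds along the chain from an amide-type nitrogen in a ring. Among the compounds with values here, none of the measured steps touches this chain. All three swap the aromatic group on oxygen: an at least 4.5-fold higher number from compound 1 to compound 2 (0.65 log units; beyond the scatter), a 2.7-fold higher number from compound 1 to compound 3 (0.44 log units; beyond the scatter), and an at least 1.6-fold lower number from compound 2 to compound 3 (0.22 log units; that floor lies within the scatter). They therefore give no direct measure for the new change and serve only as a rough yardstick. The modest step to compound 3 came from moving a single methoxy group, and adding one methyl is a similarly small edit. A step no larger than that one is expected, with no firm direction, and most likely none beyond the scatter. The expected outcome is a 1.1-fold lower number from compound 1 to compound 4 (0.04 log units; within the scatter). For compound 4 the estimated value in this assay is 20000 nM, with an expected range from 7000 nM to 60000 nM.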

Compound 4, half-maximal inhibitory concentration: 25000 nM
Compound 4: middle estimate off by 1.3-fold (0.10 log units), on the low side, and the stated range covers the measured number.
By their numbers in this assay, from the lowest: compounds 1 and 4 (each within the scatter of the next); then compound 3. At a limit, above all of these: compound 2.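

In this assay, within the data shown here, the earlier compounds changed only the aromatic group on oxygen, so they said nothing about the chain on the other side of the molecule. The new step gives the first reading there: with methyl in place of hydrogen on a saturated chain carbon, two bonds along the chain from an amide-type nitrogen in a ring, the result is a 1.1-fold higher number from compound 1 to compound 4 (0.06 log units; within the scatter). Ethyl and propyl therefore cannot be told apart in this assay, whereas a shift of the methoxy group alone gave a 2.7-fold higher number from compound 1 to compound 3 (0.44 log units; beyond the scatter), and nothing shown here explains why the chain edit leaves the number within the scatter.

This is a single edit, so it shows no trend along the chain, and the compounds shown leave open whether a longer chain such as butyl, a branched chain such as isopropyl, or a chain ending in an amine or a carboxylic acid would also leave the number in place. They also leave open whether propyl would behave the same way alongside the 4-methoxyphenyl group of compound 3.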